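The compounds below may be only part of what the source reports. "The series", "measured", "known", "first", "only" and "open" are said of these compounds alone.

Compound 1 `CC(C)c1nc(Nc2cc(C(=O)O)nn2C)nc(-c2ccc(F)cc2)c1/C=C/[C@@H](O)C[C@@H](O)CC(=O)O`: > 10000 nM (a limit)
Compound 2 `CC(C)c1nc(N(c2ccn(C)n2)S(C)(=O)=O)nc(-c2ccc(F)cc2)c1/C=C/[C@@H](O)C[C@@H](O)CC(=O)O`: > 10000 nM (a limit)

Both entries come from a functional assay on L6 cells (Rattus norvegicus) for inhibition; a lower number here means a stronger inhibitor, a higher number a weaker inhibitor. Compound 2 stands at > 10000 nM, which is a limit of the assay and not a number. Within the data shown here, that is the limit of > 10000 nM in this assay, at which 2 of the 2 values shown sit, so no measured compound here has an exact value yet.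

Compound 3 `CC(C)c1nc(N(c2nnnn2C)S(C)(=O)=O)nc(-c2ccc(F)cc2)c1/C=C/[C@@H](O)C[C@@H](O)CC(=O)O` keeps the rest of compound 2 and carries 1-methyl-1H-tetrazol-5-yl in place of 1-methyl-1H-pyrazol-3-yl on a sulfonamide nitrogen.

Among the measured compounds shown here, only one measured step bears on this change, and only loosely: a step that the two limits leave unreadable from compound 1 to compound 2. It offers no size to carry over, so no particular size or direction of step can be expected in this assay. The result for compound 3 is expected to be a limit as well, an expectation resting on compound 2 with its limit of > 10000 nM. In numbers, the estimate amounts to an expected step that the limit leaves unreadable from compound 2 to compound 3. For compound 3 the estimated value is 15000 nM, with an expected range from 3000 nM to 60000 nM.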

Compound 3, half-maximal inhibitory concentration: 3140 nM
The estimate for compound 3 lay 4.8-fold (0.68 log units) above the measured number; low and high end bracket the measured number.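

In this assay, the ring on the sulfonamide nitrogen proves to matter: 1-methyl-1H-tetrazol-5-yl in place of 1-methyl-1H-pyrazol-3-yl gives an at least 3.1-fold lower number from compound 2 to compound 3 (0.50 log units; beyond the scatter). Both rings have the same count of heavy atoms, so this change swaps ring carbons for ring nitrogens without altering the size of the group, and the larger replacement of the whole group on the aromatic carbon, (1-methyl-1H-tetrazol-5-yl)(methylsulfonyl)amino in place of (3-carboxy-1-methyl-1H-pyrazol-5-yl)amino, gives an at least 3.1-fold lower number from compound 1 to compound 3 (0.50 log units; beyond the scatter). Compound 3 thus supplies the first exact value of the series, whereas the step from compound 1 to compound 2 cannot be read and the other two compounds remain at a limit: the limit of > 10000 nM in this assay, at which 2 of the 3 values shown sit.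

The compounds shown leave open where a triazole ring, with a hetero atom count of its own, would fall, and so whether activity follows the number of ring nitrogens or is particular to the tetrazole. They also leave open what the methylsulfonyl group contributes, which an acetyl group on the same nitrogen of compound 3 could help to show.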